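A few compounds are considered here, and "the series" means these few. Any claim that something is new, unique, unknown or untested is made for them only; others in the source may bear on it.

Compounds measured in an assay on IM-9 cells for displacement of a labelled ligand from Substance-P receptor (Homo sapiens), read by scintillation counting, with a stated time of 30 min; a higher number here means a weaker inhibitor, a lower number a stronger inhibitor: compound 1 `CC(=O)NCC(=O)N1CC[C@@H](C(=O)N(C)Cc2cc(C(F)(F)F)cc(C(F)(F)F)c2)[C@H](c2ccccc2)C1` gives 12 nM; compound 2 `CC(=O)N1CCC(C(=O)N2CC[C@H](C(=O)N(C)Cc3cc(C(F)(F)F)cc(C(F)(F)F)c3)[C@@H](c3ccc(C)cc3)C2)CC1` gives 0.18 nM; compound 3 `CC(=O)N1CCC(C(=O)N2CC[C@H](C(=O)N(C)Cc3cc(C(F)(F)F)cc(C(F)(F)F)c3)[C@@H](c3cccc(C)c3)C2)CC1` gives 0.14 nM.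

Compound 3 stands at the lowest of the three numbers in this assay. Its nearest neighbour is compound 2, the difference being a 1.3-fold lower number from compound 2 to compound 3 (0.11 log units; within the scatter). Compound 1 lies far beyond the scatter from it, and also differs in the acyl group on the ring nitrogen, so it does not inform the phenyl change.

Compound 4 `CCc1ccccc1[C@H]1CN(C(=O)C2CCN(C(C)=O)CC2)CC[C@@H]1C(=O)N(C)Cc1cc(C(F)(F)F)cc(C(F)(F)F)c1` differs from compound 3 by 2-ethylphenyl in place of 3-methylphenyl on a saturated ring carbon. For the measured compounds named here, the only measured step on this phenyl, a 1.3-fold lower number from compound 2 to compound 3 (0.11 log units; within the scatter), moved a methyl without effect beyond the scatter; no measured step introduces an ethyl group. A small rise in this assay, a 4.3-fold higher number from compound 3 to compound 4 (0.63 log units; beyond the scatter), is therefore expected for compound 4, with wide uncertainty. Compound 4 is estimated at 0.6 nM, range 0.1 nM to 4 nM.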

Compound 4, half-maximal inhibitory concentration: 0.064 nM
Estimate against measurement, compound 4: 9.4-fold (0.97 log units) above; the whole stated range lies above it.
By their numbers in this assay, from the lowest: compound 4; then compounds 3 and 2 (each within the scatter of the next); then compound 1.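

In this assay, the phenyl on the saturated ring carbon accepts 2-ethylphenyl with a real gain, unlike the earlier methyl move: a 2.2-fold lower number from compound 3 to compound 4 (0.34 log units; beyond the scatter), and a 2.8-fold lower number from compound 2 to compound 4 (0.45 log units; beyond the scatter). For the compounds shown here, this is the first change on this phenyl to separate two compounds beyond the scatter, and both steps are modest. No available measurement bears on the cause of this gain.

The change alters both the chain and its place on the phenyl, so the share of each remains unresolved. From the compounds shown here alone, what a propyl chain or an amine on this phenyl would do is also open.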